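A few compounds are considered here, and "the series" means these few. Any claim that something is new, unique, unknown or untested is made for them only; others in the source may bear on it.

Working notes on the series. The parent, compound 1 `CS(=O)(=O)c1ccc(-c2[nH]ccc2-c2ccc(F)cc2)cc1`, is known in a functional assay on the whole organism with Rattus norvegicus as the target (on this read-out higher numbers stand for an effect only at larger amounts of compound and lower numbers for an effect already at smaller amounts), only by a limit of the assay: compound 1 gives > 100 mg/kg, and this is a limit, not a number. Compound 2 `CS(=O)(=O)c1ccc(-c2[nH]c(Br)cc2-c2ccc(F)cc2)cc1` carries bromo in place of hydrogen on an aromatic carbon, and in this assay compound 2 gives 1.05 mg/kg. Within the data shown here, the single measured step, an at least 95-fold lower number from compound 1 to compound 2 (1.97 log units; beyond the scatter), is therefore anchored on one side by the limit of > 100 mg/kg in this assay, at which 1 of the 2 values shown sits, and gives the only number in the set, so compound 2 stands as the one compound with a finite value. Compound 3 `CS(=O)(=O)c1ccc(-c2[nH]c(S(C)(=O)=O)cc2-c2ccc(F)cc2)cc1` differs from compound 2 by methylsulfonyl in place of bromo on an aromatic carbon. The measured step shows that substitution at this aromatic carbon moves the read-out strongly, but it was a step away from hydrogen, not an exchange of one substituent for another, so the direction for compound 3 is not fixed by it. Compound 3 is expected to stay within the same order as compound 2, with a step of a 4.8-fold higher number from compound 2 to compound 3 (0.68 log units; beyond the scatter) estimated. The estimate for compound 3 in this assay is 5 mg/kg, with a range from 0.8 mg/kg to 50 mg/kg.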

Compound 3, dose for half-maximal effect: 36.6 mg/kg
Compound 3: middle estimate off by 7.3-fold (0.86 log units), on the low side, within the range that was stated.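

In this assay, the position next to the ring nitrogen separates one substituent from another, not just a substituent from hydrogen: methylsulfonyl in place of bromo gives a 35-fold higher number from compound 2 to compound 3 (1.54 log units; beyond the scatter). Methylsulfonyl in place of hydrogen still gives an at least 2.7-fold lower number from compound 1 to compound 3 (0.43 log units; beyond the scatter), so a substituent at this carbon does not by itself carry the whole of an at least 95-fold lower number from compound 1 to compound 2 (1.97 log units; beyond the scatter). Compound 1 gives a limit, not a number, so the step from hydrogen to methylsulfonyl is only a bound: the limit of > 100 mg/kg in this assay, at which 1 of the 3 values shown sits.

Bromo and methylsulfonyl differ at once in heavy atoms and in hydrogen-bond acceptors, and the compounds shown do not pull these apart. On these data alone, whether chloro, methyl, an amine or a carboxylic acid at this carbon would fall nearer compound 2 or nearer compound 3 stays open.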